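A further methoxy on compound 3

A few compounds are considered here, and "the series" means these few. Any claim that something is new, unique, unknown or untested is made for them only; others in the source may bear on it.

Values so far in a functional assay on A549 cells (Homo sapiens) for inhibition, read by MTT assay, with a stated time of 24 h (on this read-out higher numbers stand for weaker inhibition of growth and lower numbers for stronger inhibition of growth), for three compounds:
compound 1 `COc1ccc(C(=O)n2c(-c3cn(C)c4ccccc34)nc3ccccc32)cc1OC` gives 3100 nM
compound 2 `COc1ccc2c(c1)c(-c1nc3ccccc3n1C(=O)c1ccccc1OC)cn2C` gives 11900 nM
compound 3 `COc1cccc(C(=O)n2c(-c3cn(C)c4ccc(OC)cc34)nc3ccccc32)c1` gives 4600 nM

Compound 3 lies within the scatter of compound 1 and beyond the scatter of compound 2 in this assay on these numbers. Compound 4 `COc1ccc2c(c1)c(-c1nc3ccccc3n1C(=O)c1ccc(OC)c(OC)c1)cn2C` differs from compound 3 by one change methoxy in place of hydrogen on an aromatic carbon that turns 3-methoxyphenyl to 3,4-dimethoxyphenyl. Among the compounds with values here, the only measured step on this group is a 2.6-fold lower number from compound 2 to compound 3 (0.41 log units; beyond the scatter) and it moves a methoxy rather than adding one. Compound 1 carries 3,4-dimethoxyphenyl on a different core and gives 3100 nM in this assay so no shift beyond the scatter is expected. The expected change is a 1.2-fold lower number from compound 3 to compound 4 (0.08 log units; within the scatter) and no larger. Compound 4 is estimated at 3800 nM with 1600 nM to 9000 nM as its expected range.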

Compound 4, concentration for 50% growth inhibition: 2700 nM
For compound 4 the middle estimate is 1.4-fold (0.15 log units) above the measured one, within the range that was stated.
By their numbers in this assay, from the lowest: compounds 4, 1 and 3 (each within the scatter of the next); then compound 2.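

In this assay the new methoxy, ortho to a methoxy group and para to a large group, gives a 1.7-fold lower number from compound 3 to compound 4 (0.23 log units; within the scatter), so this position accepts the added group with no shift that stands clear of the scatter. Set against 2-methoxyphenyl, the 3,4-dimethoxyphenyl group gives a 4.4-fold lower number from compound 2 to compound 4 (0.64 log units; beyond the scatter), a larger step than the move of a single methoxy. The methoxy on the other part of the molecule gives a 1.1-fold lower number from compound 1 to compound 4 (0.06 log units; within the scatter), which also stays within the scatter.

Nothing available explains these steps. On these data alone, whether an amine or a carboxylic acid at this position would keep growth inhibition stays open.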